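Halogenated benzylamine catechol series: cytotoxicity limit, iodo step

This account rests on a few compounds, and the source may have more. Where it says the series, first, only, none or still open, it means among the compounds named here.

Compound 3 `O=c1cc(CNCc2cccc(F)c2)oc2ccc(O)c(O)c12` is the reference for this step. In an ADME assay on Huh-7 cells (Homo sapiens) for cytotoxicity (on this read-out lower numbers stand for higher toxicity in this test and higher numbers for lower toxicity in this test), compound 3 gives > 100000 nM, which is a limit of the assay and not a number. Compound 1 `O=c1cc(CNCc2ccccc2Cl)oc2ccc(O)c(O)c12` in this assay gives > 100000 nM, likewise a limit. Compound 2 `O=c1cc(CNCc2ccccc2Br)oc2ccc(O)c(O)c12` in this assay gives > 100000 nM, also a limit. Compound 3 therefore cannot be placed above or below the other two; all three share (the limit of > 100000 nM in this assay, at which 3 of the 3 values shown sit). The steps a step that the two limits leave unreadable from compound 1 to compound 2, a step that the two limits leave unreadable from compound 1 to compound 3 and a step that the two limits leave unreadable from compound 2 to compound 3 are unreadable in size because the limit of > 100000 nM in this assay, at which 3 of the 3 values shown sit, covers both ends of each. The change to compound 4 `O=c1cc(CNCc2cccc(I)c2)oc2ccc(O)c(O)c12` is iodo in place of fluoro on an aromatic carbon. The halogen exchanges already measured bear on it, yet none of them yields a readable size or direction. The step that the limit leaves unreadable from compound 3 to compound 4 is therefore expected to stay within the scatter, with compound 4 again at the limit. Compound 4 is expected at 150000 nM, with a range from 50000 nM to 400000 nM.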

Compound 4, half-maximal cytotoxic concentration: > 100000 nM
Compound 4: only a limit was reported; the forecaster's own chance of this, stated with the estimate: 85%; the middle value is on the limit's open side.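

No step from compound 1, compound 2 or compound 3 to compound 4 can be read, because all four compounds share one limit: the limit of > 100000 nM in this assay, at which 4 of the 4 values shown sit.

The compounds shown leave open how far each compound lies from that limit and whether any halogen exchange changes cytotoxicity.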